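A few compounds are considered here, and "the series" means these few. Any claim that something is new, unique, unknown or untested is made for them only; others in the source may bear on it.

In a functional assay on HeLa cells (Homo sapiens) for inhibition, read by CCK-8 assay, with a stated time of 48 h (a lower number here means a stronger inhibitor, a higher number a weaker inhibitor), compound 1 `O=C1CSC(N2N=C(c3ccc(Cl)cc3)CC2c2cccc3ccccc23)=N1` gives 8840 nM, compound 2 `Fc1ccc(C2=NN(C3=NC(c4ccccc4)CS3)C(c3ccc4ccccc4c3)C2)cc1` gives 9730 nM and compound 3 `Clc1ccc(C2=NN(C3=NC(c4ccccc4)CS3)C(c3cccc4ccccc34)C2)cc1` gives 9940 nM. Compound 1 thus stands level with the other two, as all three numbers lie within the scatter of one another. Compound 4 `O=C1CSC(N2N=C(c3ccc(Br)cc3)CC2c2cccc3ccccc23)=N1` differs from compound 1 by a single exchange, bromo in place of chloro on an aromatic carbon, 4-chlorophenyl to 4-bromophenyl. Among the compounds with values here, no measured step covers this exchange. Within the data shown here, the one measured step, a 1.1-fold higher number from compound 1 to compound 3 (0.05 log units; within the scatter), lies in another place, on an amine nitrogen in a ring, and stays within the scatter. No step beyond the scatter is therefore expected in this assay. The expected step is a 1.0-fold lower number from compound 1 to compound 4 (0.02 log units; within the scatter). Compound 4 is estimated at 8500 nM, with an expected range of 4500 nM to 16000 nM.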

Compound 4, half-maximal inhibitory concentration: 5810 nM
The estimate for compound 4 lay 1.5-fold (0.17 log units) above the measured number; measured number inside the range.
By their numbers in this assay, from the lowest: compounds 4, 1, 2 and 3 (each within the scatter of the next).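

In this assay, within the data shown here, 4-bromophenyl in place of 4-chlorophenyl gives a 1.5-fold lower number from compound 1 to compound 4 (0.18 log units; within the scatter), the first reading of any change at this position on an aromatic carbon. Bromo and chloro at this place therefore cannot be told apart in this assay, which the earlier compounds, with no pair differing here, could not show. No evidence bears on this result. As far as these compounds go, whether an amine, a methoxy group or a carboxylic acid at this place would give a step beyond the scatter stays open. So does whether the same exchange would read alike on the core of compound 3.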